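This account rests on a few compounds, and the source may have more. Where it says the series, first, only, none or still open, it means among the compounds named here.

Within the data shown here, compound 3 `O=[N+]([O-])c1ccc(C2=NN(C(=S)Nc3ccccc3)C(c3ccc4c(c3)OCCO4)C2)cc1` gives 78100 nM in a functional assay on A-375 cells (Homo sapiens) for antiproliferative activity, read by MTT assay, with a stated time of 48 h (on this read-out lower numbers stand for stronger inhibition of growth and higher numbers for weaker inhibition of growth), the second highest of the three numbers so far. Compound 1 `Fc1ccc(C2=NN(C(=S)Nc3ccccc3)C(c3ccc4c(c3)OCCO4)C2)cc1` gives 15700 nM, and compound 2 `CSc1ccc(C2=NN(C(=S)Nc3ccccc3)C(c3ccc4c(c3)OCCO4)C2)cc1` gives 159000 nM. The measured steps all change one group on the same ring: a 5.0-fold higher number from compound 1 to compound 3 (0.70 log units; beyond the scatter), a 10-fold higher number from compound 1 to compound 2 (1.01 log units; beyond the scatter) and a 2.0-fold lower number from compound 2 to compound 3 (0.31 log units; beyond the scatter). Compound 4 `S=C(Nc1ccccc1)N1N=C(c2ccc(Cl)c(Cl)c2)CC1c1ccc2c(c1)OCCO2` differs from compound 3 by 3,4-dichlorophenyl in place of 4-nitrophenyl on a carbon with a double bond to nitrogen. Among the measured compounds shown here, no measured step swaps in a dichlorophenyl, but fluoro, the only other halogen, gave the lowest number, so a moderately lower number is expected, with wide uncertainty: the expected step is a 3.9-fold lower number from compound 3 to compound 4 (0.59 log units; beyond the scatter). Compound 4 is estimated at 20000 nM, between 5000 nM and 80000 nM.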

Compound 4, concentration for 50% growth inhibition: 41900 nM
Beside the measured number, compound 4's estimate is 2.1-fold (0.32 log units) below it; the measured number falls inside the stated range.
By their numbers in this assay, from the lowest: compound 1; then compounds 4 and 3 (each within the scatter of the next); then compound 2.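

In this assay, the 3,4-dichlorophenyl group on this carbon does not reach the number of the 4-fluorophenyl group, with a 2.7-fold higher number from compound 1 to compound 4 (0.43 log units; beyond the scatter), so carrying halogen does not by itself give the lowest number. Compound 3 and compound 4 cannot be told apart, with a 1.9-fold lower number from compound 3 to compound 4 (0.27 log units; within the scatter), while the methylsulfanyl compound is separated, with a 3.8-fold lower number from compound 2 to compound 4 (0.58 log units; beyond the scatter). Nothing available explains these differences.

On these data alone, how a 4-chlorophenyl or a 4-aminophenyl group on this carbon would compare stays open. The compounds shown therefore cannot separate the effect of the second chlorine from that of the kind of halogen.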